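Swapping a chain-end methyl for methoxy on a xanthine core

A few compounds are considered here, and "the series" means these few. Any claim that something is new, unique, unknown or untested is made for them only; others in the source may bear on it.

Of the compounds shown here, three sharing one core have been tested in a functional assay (trachea) with Cavia porcellus as the target; on this read-out lower numbers stand for an effect already at smaller amounts and higher numbers for an effect only at larger amounts of compound. Compound 1 `CCCn1c(=O)n(CCO)c(=O)c2[nH]cnc21` gives 510 nM. Compound 2 `CCCn1c(=O)n(CCCOC)c(=O)c2[nH]cnc21` gives 2900 nM; the only single change among these, a 5.7-fold higher number from compound 1 to compound 2 (0.75 log units; beyond the scatter), is the sole guide available. Compound 3 `CCCn1cnc2c1c(=O)n(C)c(=O)n2CCC` gives 5000 nM, the highest number of the three, though it sits within the scatter of compound 2 and is separated from compound 1 by a gap beyond the scatter.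

Compound 4 `CCCn1c(=O)n(C)c(=O)c2c1ncn2CCOC` differs from compound 3 by methoxy in place of methyl on a saturated chain carbon, two bonds along the chain from an aromatic nitrogen. Within the data shown here, no measured step makes this exact change; the nearest is the step from compound 1 to compound 2, which likewise placed a methoxy-bearing group on a saturated chain carbon two bonds along the chain from an aromatic nitrogen and raised the number modestly. Because that step, a 5.7-fold higher number from compound 1 to compound 2 (0.75 log units; beyond the scatter), started from a hydroxy rather than a methyl, its transfer is uncertain, so the expected step of a 1.2-fold higher number from compound 3 to compound 4 (0.08 log units; within the scatter) is small and could fall within the scatter. Compound 4 is expected to give 6000 nM, with a range of 2000 nM to 18000 nM in this assay.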

Compound 4, half-maximal effective concentration: 36100 nM
For compound 4 the middle estimate is 6.0-fold (0.78 log units) below the measured one, outside the stated range (above it).
By their numbers in this assay, from the lowest: compound 1; then compounds 2 and 3 (each within the scatter of the next); then compound 4.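

On a saturated chain carbon, two bonds along the chain from an aromatic nitrogen, methoxy in place of methyl is no neutral swap in this assay: it brings a 7.2-fold higher number from compound 3 to compound 4 (0.86 log units; beyond the scatter). The earlier step, a 5.7-fold higher number from compound 1 to compound 2 (0.75 log units; beyond the scatter), started from a hydroxy, which left open whether losing that hydroxy was what mattered; here no hydroxy is involved, and the number still rises when propyl becomes 2-methoxyethyl. Nothing given here explains this rise.

On these data alone, it remains open whether the rise belongs to the methoxy itself or would appear with other groups at this place. An amine or a carboxylic acid at the chain end, or a longer chain ending in methoxy, could push the number further up or bring it back down.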